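The source may hold more compounds than are shown below. What is called first, only, known or untested is meant among the compounds shown, and "the series" means these compounds.

In a functional assay on HT-29 cells (Homo sapiens) for inhibition, read by MTT assay, with a stated time of 48 h (a lower number here means a stronger inhibitor, a higher number a weaker inhibitor), compound 1, `COc1ccc(-n2c(SCC(=O)Nc3ccc(Cl)cc3)nnc2-c2cc(OC)c(OC)c(OC)c2)cc1`, gives 58000 nM. Compound 2, `COc1cc(-c2nnc(SC)n2-c2ccc(N(C)C)cc2)cc(OC)c1OC`, is a separate case: in this assay compound 2 reaches only > 60000 nM, which is a limit of the assay and not a number. Compound 2 therefore stands at the top of the values shown, and of the two values shown it is the one sitting at the limit described by the limit of > 60000 nM in this assay, at which 1 of the 2 values shown sits. Among the compounds with values here, no step between the two measured compounds is given, since they differ in more than one place, so their two values only show that neither compound is a strong inhibitor.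

Compound 3, `COc1ccc(NC(=O)CSc2nnc(-c3cc(OC)c(OC)c(OC)c3)n2-c2ccc(N(C)C)cc2)cc1`, is not yet measured. It differs from compound 2 as follows: (4-methoxyphenyl)carbamoyl in place of hydrogen on a saturated chain carbon bound to a sulfur. With compound 1 carrying a related carbamoyl chain and giving 58000 nM, no sizeable gain beyond the scatter is expected from this change, and the step from compound 2 to compound 3 is estimated at a number no higher from compound 2 to compound 3 (the limit leaves the size open), that is, none beyond the scatter. Compound 3 is accordingly expected to give about 60000 nM in this assay, within 25000 nM to 150000 nM.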

Compound 3, half-maximal inhibitory concentration: 51400 nM
The estimate for compound 3 lay 1.2-fold (0.07 log units) above the measured number; the measured number falls inside the stated range.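

Replacing hydrogen with (4-methoxyphenyl)carbamoyl on a saturated chain carbon bound to a sulfur, which turns methyl into ((4-methoxyphenyl)carbamoyl)methyl, gives in this assay an at least 1.1-fold lower number from compound 2 to compound 3 (0.06 log units; that floor lies within the scatter). The earlier compounds shown here offered no step at this position, and this one shows that the change leaves the series weak: compound 3 gives 51400 nM, a measurable number, yet this does not establish any gain beyond the scatter. The true size of the step stays open because compound 2 carries a limit of the assay and not a number: the limit of > 60000 nM in this assay, at which 1 of the 3 values shown sits.

Compound 1 and compound 3 differ in more than one place, so the part played by the chlorine on the anilide ring, or by the group on the other aryl ring, cannot be separated from these values. The compounds shown also leave open how a carboxylic acid or an amine in place of the (4-methoxyphenyl)carbamoyl group, or a longer chain between the sulfur and the carbonyl, would read in this assay.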